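The compounds below may be only part of what the source reports. "The series", "measured", "known", "first", "only" and "open" are said of these compounds alone.

Three compounds of one shared core have been examined. Compound 1 `[O-][n+]1nc(NCc2ccccc2Cl)[n+]([O-])c2ccccc21` gives 10600 nM in a functional assay on PC-3 cells (Homo sapiens) for cytotoxicity, read by MTT assay, with a stated time of 48 h; on this read-out lower numbers stand for stronger inhibition and higher numbers for weaker inhibition. Compound 2 `COc1ccc(Nc2n[n+]([O-])c3ccccc3[n+]2[O-])cc1` gives 12000 nM in this assay, and compound 3 `[O-][n+]1nc(NC2CCCCC2)[n+]([O-])c2ccccc21` gives 10500 nM. Compound 1 thus stands second highest of the three numbers, while its gaps to compound 3 and to compound 2 both lie within the scatter, so no order among the three can be drawn. Compound 4 `CCCCCCCCNc1n[n+]([O-])c2ccccc2[n+]1[O-]` differs from compound 1 by heptyl in place of 2-chlorophenyl on a saturated chain carbon bound to a nitrogen on an aromatic ring. Within the data shown here, no step between measured compounds is known, and since the three measured values lie within the scatter of one another, only a small step in either direction is expected, none clearly beyond the scatter. The step from compound 1 to compound 4 is estimated at a 1.1-fold lower number from compound 1 to compound 4 (0.03 log units; within the scatter). Compound 4 is accordingly expected to give about 10000 nM in this assay, within a range from 4000 nM to 25000 nM.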

Compound 4, half-maximal inhibitory concentration: 18200 nM
Estimate against measurement, compound 4: 1.8-fold (0.26 log units) below; measured number inside the range.
By their numbers in this assay, from the lowest: compounds 3, 1, 2 and 4 (each within the scatter of the next).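

In this assay, heptyl in place of 2-chlorophenyl on a saturated chain carbon bound to a nitrogen on an aromatic ring gives a 1.7-fold higher number from compound 1 to compound 4 (0.23 log units; within the scatter) and so stays within the scatter. This first one-place comparison shows that, at this position, an open chain and a chlorinated aromatic ring cannot be told apart in this read-out. Nothing available bears on the reason for this result.

On these data alone, whether a longer chain or a heptyl chain carrying a carboxylic acid would move the number beyond the scatter remains open.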